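A Bromo Group Added to Compound 2

The source may hold more compounds than are shown below. What is called first, only, known or untested is meant among the compounds shown, and "the series" means these compounds.

Two related compounds have been measured so far. In a functional assay on PC-3 cells (Homo sapiens) for antiproliferative activity, read by MTT assay, with a stated time of 72 h (a lower number here means a stronger inhibitor, a higher number a weaker inhibitor), compound 1 `N#Cc1ccc(/C=N/NC(=O)Nc2ccc(Oc3ccnc4[nH]ccc34)c(F)c2)cc1` gives 9030 nM, while compound 2 `O=C(N/N=C/c1ccc(O)cc1)Nc1ccc(Oc2ccnc3[nH]ccc23)c(F)c1` gives 2780 nM. Compound 2 therefore holds the lower of the two numbers, which makes it the stronger inhibitor of this pair.

The next compound, compound 3 `O=C(N/N=C/c1ccc(O)c(Br)c1)Nc1ccc(Oc2ccnc3[nH]ccc23)c(F)c1`, keeps all of compound 2 and makes one change: bromo in place of hydrogen on an aromatic carbon. A bromo group takes the place of hydrogen on an aromatic carbon, ortho to a hydroxy group.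

Going by the values given here, only one measured step offers any guidance. The step of a 3.2-fold lower number from compound 1 to compound 2 (0.51 log units; beyond the scatter) is modest and comes from hydroxy in place of cyano on an aromatic carbon. It shows that a single swap on this ring can move the number beyond the scatter, but it is a different change. Among the compounds with values here, no measured pair shows what bromo does here, so the direction is uncertain.

A small step toward a lower number in this assay is a cautious expectation, and it may stay within the scatter. The estimated change is a 1.4-fold lower number from compound 2 to compound 3 (0.14 log units; within the scatter). For compound 3 the expected value is 2000 nM, with an estimated range of 700 nM to 6000 nM.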

Compound 3, half-maximal inhibitory concentration: 28600 nM
For compound 3 the middle estimate is 14-fold (1.16 log units) below the measured one; measured number outside the range, above it.
By their numbers in this assay, from the lowest: compound 2; then compound 1; then compound 3.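

In this assay, one bromo group on an aromatic carbon, ortho to a hydroxy group, gives a 10-fold higher number from compound 2 to compound 3 (1.01 log units; beyond the scatter), a large step toward a weaker inhibitor. This shows that the position is far from indifferent: adding a single heavy atom here moves the number further than the modest earlier swap of cyano for hydroxy, which gave a 3.2-fold lower number from compound 1 to compound 2 (0.51 log units; beyond the scatter). The gain from that swap also fails to survive the added bromo, since replacing the whole 4-cyanophenyl with 3-bromo-4-hydroxyphenyl gives a 3.2-fold higher number from compound 1 to compound 3 (0.50 log units; beyond the scatter), so this group ends up weaker than the nitrile-bearing one it replaces, and no measurement at hand explains why the number rises.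

On these data alone, what stays open is whether this loss belongs to bromo in particular or would follow any group placed on this carbon, a question that a fluoro, a chloro or a methyl group at the same place could help to settle. As far as these compounds go, it is also open whether bromo would cost as much if a methoxy group or an amine stood in place of the hydroxy group.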